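Adding a Second Chlorine to a Benzyl-Substituted Purine Core

The source may report more compounds than this note shows. Statements on the series, on what has been measured and on what is new or still open speak of the compounds shown alone.

Measured compounds, in a functional assay on Hs-578T cells (Homo sapiens) for cytotoxicity, read by sulforhodamine B assay, with a stated time of 48 h; a lower number here means a stronger inhibitor of growth, a higher number a weaker inhibitor of growth:
compound 1, `ClCc1cccc(Cn2cnc3ncnc(Cl)c32)c1`: 42700 nM
compound 2, `ClCc1ccccc1Cn1cnc2ncnc(Cl)c21`: 6020 nM
compound 3, `ClCc1ccc(Cn2cnc3c(Cl)nc(Cl)nc32)cc1`: 5750 nM

Among these three numbers, compound 2 stands second highest. Its closest neighbour is compound 3, whose value lies within the scatter of repeated measurements, so the two cannot be told apart. The furthest is compound 1, whose higher number marks it as the weaker growth inhibitor of the set, with a gap beyond the scatter.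

Compound 4, `ClCc1ccccc1Cn1cnc2nc(Cl)nc(Cl)c21`, has not yet been measured in this assay. It differs from compound 2 in one place: chloro in place of hydrogen on an aromatic carbon. Among the compounds with values here, compound 3 also carries two chlorines on its core, though on a different benzyl pattern, so there is no directly comparable pair to show what this change does. Without such a pair, the expectation is a step no larger than the scatter, if anything toward a slightly lower number; compound 4 is expected to show a 1.5-fold lower number from compound 2 to compound 4 (0.18 log units; within the scatter). The estimate for compound 4 is therefore 4000 nM, with a range from 1500 nM to 12000 nM.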

Compound 4, concentration for total growth inhibition: 2570 nM
Estimate against measurement, compound 4: 1.6-fold (0.19 log units) above; measured number inside the range.
By their numbers in this assay, from the lowest: compound 4; then compounds 3 and 2 (each within the scatter of the next); then compound 1.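

Within the data shown here, putting chloro in place of hydrogen on the aromatic carbon between two ring nitrogen atoms gives, in this assay, a 2.3-fold lower number from compound 2 to compound 4 (0.37 log units; beyond the scatter) and is the first change in this set that can be read in one place. The step is modest, yet it shows that this position accepts a chloro group, one added heavy atom, and that growth inhibition gets stronger rather than weaker. Nothing at hand explains why the number falls.

A single group at this carbon cannot show whether chloro is special there, and an amine, a methoxy group or a fluorine in its place would test that. As far as these compounds go, it also remains open whether the same change would lower the number on compound 1, which has a different benzyl pattern.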